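The source may hold more compounds than are shown below. What is called first, only, known or untested is meant among the compounds shown, and "the series" means these compounds.

Measured compounds: compound 1 `Cc1n[nH]c2ccc(-c3nc4cnc(N5CCN(C)CC5)cn4c3Nc3ccc(Br)cc3Cl)cc12`, which in a functional assay on MV4-11 cells (Homo sapiens) for inhibition, with a stated time of 120 h (on this read-out lower numbers stand for stronger inhibition and higher numbers for weaker inhibition), as compound 1 gives 9220 nM; compound 2 `COc1ccc(Nc2c(-c3ccc4[nH]nc(C)c4c3)nc3cnc(N4CCN(C)CC4)cn23)cc1OC`, for which in this assay compound 2 gives "not determined" (no result reported), no result being reported.

Compound 2 therefore stands nowhere on the numbers shown: it carries no value of its own. The change from compound 2 to compound 3 `Cc1n[nH]c2ccc(-c3nc4cnc(N5CCN(C)CC5)cn4c3Nc3ccc(Cl)cc3Cl)cc12` is 2,4-dichlorophenyl in place of 3,4-dimethoxyphenyl on a nitrogen on an aromatic ring. Since compound 2 has no number, neither the size nor the direction of this step can be read from the data, and none is claimed. Compound 3 is nonetheless expected to be weak in this assay because compound 1 gives 9220 nM. Compound 3 is estimated at 8000 nM, within a range from 2500 nM to 25000 nM.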

Compound 3, half-maximal inhibitory concentration: 4720 nM
The estimate for compound 3 lay 1.7-fold (0.23 log units) above the measured number; the measured number falls inside the stated range.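

In this assay, chloro in place of bromo on an aromatic carbon gives a 2.0-fold lower number from compound 1 to compound 3 (0.29 log units; within the scatter), so the two halogens at this place cannot be told apart on these numbers. Compound 2 has no number, so the step from it to compound 3 cannot be read, and the (2,4-dichlorophenyl)amino group cannot be compared with the (3,4-dimethoxyphenyl)amino group. No measurement shown here accounts for this result. From the compounds shown here alone, it remains open whether an amine or a carboxylic acid in place of the bromo or chloro would give a clearly different number.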